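Removing a Ring Fluorine: Expected Growth Inhibition of Compound 4

A few compounds are considered here, and "the series" means these few. Any claim that something is new, unique, unknown or untested is made for them only; others in the source may bear on it.

Measured so far in a functional assay on HeLa cells (Homo sapiens) for inhibition, read by CCK-8 assay, with a stated time of 72 h, tested at 1 uM; on this read-out lower numbers stand for less inhibition of growth and higher numbers for more inhibition of growth at the one concentration tested:
Compound 1, `CN(C)C(=O)c1cc2cnc(Nc3ccc(NC(=O)C4(C(=O)Nc5cccc(O)c5)CC4)cc3)nc2n1C1CCCC1`: 57%
Compound 2, `CN(C)C(=O)c1cc2cnc(Nc3ccc(NC(=O)C4(C(=O)Nc5ccc(F)cc5)CC4)cc3F)nc2n1C1CCCC1`: 6.2%
Compound 3, `Nc1ccc(NC(=O)C2(C(=O)Nc3ccc(F)cc3)CC2)cc1F`: 14%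

Compound 2 gives the lowest of these three numbers. Compound 3 sits within the scatter of compound 2, so the two cannot be told apart; compound 1 lies well beyond it. Compound 4, `CN(C)C(=O)c1cc2cnc(Nc3ccc(NC(=O)C4(C(=O)Nc5ccc(F)cc5)CC4)cc3)nc2n1C1CCCC1`, has not been measured yet. It differs from compound 2 in one place: hydrogen in place of fluoro on an aromatic carbon. Among the compounds with values here, no measured pair shows this change on its own. Compound 1, which also carries hydrogen at that place but a different group on its other ring, reaches 57%, so a rise for compound 4 is expected, though its size is uncertain. The expected step of a number 23.8 percentage points higher from compound 2 to compound 4 (beyond the scatter) carries a wide range. Compound 4 is estimated at 30%, between 5% and 60%.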

Compound 4, percent growth inhibition at one concentration: 49.8%
Beside the measured number, compound 4's estimate is 19.8 percentage points below it, and the stated range covers the measured number.
By their numbers in this assay, from the lowest: compounds 2 and 3 (each within the scatter of the next); then compounds 4 and 1 (each within the scatter of the next).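

In this assay, within the data shown here, hydrogen in place of fluoro on this aromatic carbon gives a number 43.6 percentage points higher from compound 2 to compound 4 (beyond the scatter), the first view of this change on its own, and a large one. With hydrogen at this place, 4-fluorophenyl in place of 3-hydroxyphenyl gives a number 7.2 percentage points lower from compound 1 to compound 4 (within the scatter), so these two compounds cannot be told apart. Nothing available explains why this single atom change has so large an effect. From the compounds shown here alone, whether other groups at this place, such as chloro or methoxy, would behave like fluoro or like hydrogen stays open. Going by these compounds, whether the same change has a similar effect with the 3-hydroxyphenyl group also stays open.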